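Adding a Methoxy Group: One Measured Step, One Expected

This account rests on a few compounds, and the source may have more. Where it says the series, first, only, none or still open, it means among the compounds named here.

Measured compounds:
compound 1, `COc1cc(-c2cc(/C=C/C(=O)c3ccc(N)cc3)[nH]n2)cc(OC)c1OC`: 1740 nM in a functional assay on COLO 205 cells (Homo sapiens) for inhibition, read by sulforhodamine B assay, with a stated time of 48 h; a higher number here means a weaker inhibitor of growth, a lower number a stronger inhibitor of growth
compound 2, `COc1ccc(C(=O)/C=C/c2cc(-c3cc(OC)c(OC)c(OC)c3)n[nH]2)cc1OC`: 1740 nM in this assay
compound 3, `COc1ccc(-c2cc(/C=C/C(=O)c3ccc(N)cc3)[nH]n2)cc1OC`: 1880 nM in this assay

The three measured compounds sit close together. Compound 3 and compound 1 differ in one place, (methoxy in place of hydrogen on an aromatic carbon), and that change gave a 1.1-fold lower number from compound 3 to compound 1 (0.03 log units; within the scatter). Compound 1 and compound 2 differ by a 3,4-dimethoxyphenyl in place of a 4-aminophenyl on a carbonyl carbon, a step of no change at the digits printed from compound 1 to compound 2 (within the scatter). The difference between the core of compound 2 and the core of compound 3 is not broken down here; their two values in this assay lie within the usual scatter of each other, so no order among the three can be read from these numbers.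

Compound 4, `COc1cc(C(=O)/C=C/c2cc(-c3cc(OC)c(OC)c(OC)c3)n[nH]2)cc(OC)c1OC`, has not yet been measured. It differs from compound 2 by methoxy in place of hydrogen on an aromatic carbon. The surroundings of this change are described in the same words as for the change from compound 3 to compound 1, so it is the same change, seen here for the second time among these compounds. Because the earlier instance gave a 1.1-fold lower number from compound 3 to compound 1 (0.03 log units; within the scatter), the step from compound 2 to compound 4 is expected to be a 1.0-fold lower number from compound 2 to compound 4 (0.01 log units; within the scatter) in this assay. This expectation rests on a single earlier step and on nothing more. Compound 4 is therefore estimated at 1700 nM in this assay, with an expected range from 850 nM to 3400 nM.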

Compound 4, concentration for 50% growth inhibition: 1750 nM
The estimate for compound 4 lay 1.0-fold (0.01 log units) below the measured number; the measured number falls inside the stated range.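

In this assay, methoxy in place of hydrogen on an aromatic carbon gave a 1.0-fold higher number from compound 2 to compound 4 (0.00 log units; within the scatter), so the second instance of this change, like the first, produced no step beyond the scatter. The two instances also agree with each other, and the change carried from one core to the other without any visible difference between them: the same change on two cores in this assay, a 1.1-fold lower number (0.03 log units; within the scatter) from compound 3 to compound 1 and a 1.0-fold higher number (0.00 log units; within the scatter) from compound 2 to compound 4, 1.1-fold (0.04 log units) apart, within the scatter of two such steps

This shows that, on these two cores and in this one assay, the added methoxy group leaves the growth-inhibition number where it was, but it does not show that the same would hold on any other core, and two pairs cannot separate a small real effect from none at all.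

The compounds shown leave open whether a different group at the same aromatic carbon, such as a hydroxyl, an ethoxy group or a chlorine atom, would give a step beyond the scatter where methoxy gives none. They also leave open what would move the number in this series at all, as every value shown lies within the scatter of the others, and whether an amine on the ring that carries the added methoxy group would behave as the methoxy groups do.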